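A few compounds are considered here, and "the series" means these few. Any claim that something is new, unique, unknown or untested is made for them only; others in the source may bear on it.

Series notes. Compound 1 `O=c1cc(-c2ccc([N+](=O)[O-])cc2)oc2cc(O)ccc12` and compound 2 `O=c1cc(-c2ccc([N+](=O)[O-])cc2)oc2c(O)c(O)ccc12` share one core; compound 3 `COc1cc(-c2cc(=O)c3ccc(O)cc3o2)cc(OC)c1O[Si](C)(C)C(C)(C)C` carries another, and the difference between the two cores is not broken down here. Compound 4 `COc1cc(-c2cc(=O)c3ccc(O)c(O)c3o2)cc(OC)c1O[Si](C)(C)C(C)(C)C` is compound 3 with hydroxy in place of hydrogen on an aromatic carbon. In a functional assay on Malme-3M cells (Homo sapiens) for cytotoxicity, read by MTT assay, with a stated time of 6 days (a lower number here means that less compound is needed, a higher number that more compound is needed for the effect), compound 1 gives only a limit, > 25 ug/mL. Compound 2 gives 3.61 ug/mL in this assay, with hydroxy in place of hydrogen on an aromatic carbon, and the step is an at least 6.9-fold lower number from compound 1 to compound 2 (0.84 log units; beyond the scatter). Compound 3 gives only a limit in this assay, > 25 ug/mL. Note (the limit of > 25 ug/mL in this assay, at which 2 of the 3 values shown sit). The change from compound 3 to compound 4 is the same as that from compound 1 to compound 2, the place of the change matching word for word. The expected step is an at least 3.1-fold lower number from compound 3 to compound 4 (0.49 log units; beyond the scatter), resting on an at least 6.9-fold lower number from compound 1 to compound 2 (0.84 log units; beyond the scatter). Compound 4 is estimated at 8 ug/mL, between 2.5 ug/mL and 25 ug/mL.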

Compound 4, concentration for half-maximal effect: 0.2 ug/mL
The estimate for compound 4 lay 40-fold (1.60 log units) above the measured number; measured number outside the range, below it.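

In this assay, hydroxy in place of hydrogen on an aromatic carbon also lowers the number on the second core, giving an at least 120-fold lower number from compound 3 to compound 4 (2.09 log units; beyond the scatter). The direction of the change therefore carries over between the two cores, on these two pairs only, while any difference in step size stays unresolved: the same change on two cores in this assay, an at least 6.9-fold lower number (0.84 log units; beyond the scatter) from compound 1 to compound 2 and an at least 120-fold lower number (2.09 log units; beyond the scatter) from compound 3 to compound 4; the limit leaves it open whether they differ. Neither step has an exact size, since compound 1 and compound 3 each stand at a limit: the limit of > 25 ug/mL in this assay, at which 2 of the 4 values shown sit.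

Open, as far as these compounds go, is whether a methoxy group or an amine on that aromatic carbon would give a step of the same kind. Also open, from the compounds shown here alone, is whether the step would hold on a core carrying a carboxylic acid.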